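Replacing the boron-bearing group of compound 1 with hydrogen

A few compounds are considered here, and "the series" means these few. Any claim that something is new, unique, unknown or untested is made for them only; others in the source may bear on it.

Compound 1 (`O=C(c1ccc2cccc(OCc3ccc(B(O)O)cc3)c2n1)N1CCC(Oc2no[n+]([O-])c2S(=O)(=O)c2ccccc2)CC1`) gives 3050 nM in a functional assay on SW1990 cells (Homo sapiens) for cytotoxicity, read by MTT assay, with a stated time of 48 h, in the presence of a further agent that is not named here (on this read-out lower numbers stand for stronger inhibition and higher numbers for weaker inhibition), and compound 2 (`CC1(C)OB(c2ccc(COc3cccc4ccc(C(=O)N5CCC(Oc6no[n+]([O-])c6S(=O)(=O)c6ccccc6)CC5)nc34)cc2)OC1(C)C`) gives 2880 nM so the two stand level within the scatter. Compound 3 (`O=C(c1ccc2cccc(O)c2n1)N1CCC(Oc2no[n+]([O-])c2S(=O)(=O)c2ccccc2)CC1`) differs from compound 1 by a hydrogen atom in place of a group of 10 heavy atoms (7 carbon, 1 boron, 2 oxygen; one six-membered aromatic ring of carbon only), on an oxygen on an aromatic ring and has no measured value yet. Going by the values given here, the one measured step (a 1.1-fold lower number from compound 1 to compound 2 (0.02 log units; within the scatter)) alters only the boron-bearing part of that group, so it bears on the change only in part. Among the compounds with values here, no measured step removes the whole group, which leaves the expectation loose. The expected size is a 1.4-fold lower number from compound 1 to compound 3 (0.14 log units; within the scatter) and stays within the scatter. Compound 3 is estimated at 2200 nM (expected range 700 nM to 6000 nM).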

Compound 3, half-maximal inhibitory concentration: 790 nM
Estimate against measurement, compound 3: 2.8-fold (0.44 log units) above; low and high end bracket the measured number.
By their numbers in this assay, from the lowest: compound 3; then compounds 2 and 1 (each within the scatter of the next).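

In this assay, hydrogen in place of the whole group on the oxygen gives a 3.9-fold lower number from compound 1 to compound 3 (0.59 log units; beyond the scatter) and this step lies beyond the scatter, unlike the change limited to the boron-bearing part (a 1.1-fold lower number from compound 1 to compound 2 (0.02 log units; within the scatter)). This position therefore responds to removal of the full group, which the boron-bearing change alone did not show. No evidence on hand accounts for the step.

Still open, as far as these compounds go, is whether a plain benzyl group on this oxygen, with no boron, would track compound 1 or compound 3. A methyl group there would test whether a much smaller group keeps the number of compound 3.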